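Methyl Extension on a Lactone and an Ether Core

This account rests on a few compounds, and the source may have more. Where it says the series, first, only, none or still open, it means among the compounds named here.

The set comprises two cores. Compound 1 `COc1ccccc1C[C@H]1COC(=O)[C@@H]1Cc1ccc(Cl)c(Cl)c1` and compound 2 `CCOc1ccccc1C[C@H]1COC(=O)[C@@H]1Cc1ccc(Cl)c(Cl)c1` share one, and in a functional assay on HL-60 cells (Homo sapiens) for cytotoxicity, read by WST assay, with a stated time of 48 h (a lower number here means that less compound is needed, a higher number that more compound is needed for the effect), compound 1 gives 14000 nM while compound 2 gives 15000 nM. The difference between them is methyl in place of hydrogen on a saturated chain carbon bound to an oxygen on an aromatic ring, and the step of a 1.1-fold higher number from compound 1 to compound 2 (0.03 log units; within the scatter) hardly moves the read-out. Compound 3 `Cc1ccc(C[C@H]2COC[C@@H]2Cc2ccc(Cl)c(Cl)c2)cc1` carries a different core; how its core differs from that of compound 1 is not broken down here. In this assay compound 3 gives 21000 nM, and its values against compound 1 and compound 2 both lie within the scatter.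

Compound 4 `CCc1ccc(C[C@H]2COC[C@@H]2Cc2ccc(Cl)c(Cl)c2)cc1` has not been measured. It differs from compound 3 by methyl in place of hydrogen on a saturated chain carbon bound to an aromatic carbon. This is the same kind of change as that from compound 1 to compound 2, but the place is not the same: in the earlier pair the carbon is bound to an oxygen on an aromatic ring, whereas here it is bound to an aromatic carbon. Because a 1.1-fold higher number from compound 1 to compound 2 (0.03 log units; within the scatter) stayed within the scatter, the expected step from compound 3 to compound 4 is a 1.1-fold higher number from compound 3 to compound 4 (0.04 log units; within the scatter). Compound 4 is therefore estimated at 23000 nM in this assay, expected between 12000 nM and 45000 nM.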

Compound 4, half-maximal effective concentration: 26000 nM
Compound 4: the middle estimate sits 1.1-fold (0.05 log units) below what was measured, and the stated range covers the measured number.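

In this assay, methyl in place of hydrogen gives a 1.2-fold higher number from compound 3 to compound 4 (0.09 log units; within the scatter), and the two steps for this change agree: the same change on two cores in this assay, a 1.1-fold higher number (0.03 log units; within the scatter) from compound 1 to compound 2 and a 1.2-fold higher number (0.09 log units; within the scatter) from compound 3 to compound 4, 1.2-fold (0.06 log units) apart, within the scatter of two such steps. On these two cores, then, the change leaves the read-out within the scatter, whether the carbon receiving the methyl is bound to an oxygen on an aromatic ring, as in compound 2, or to an aromatic carbon, as in compound 4. Among the compounds shown here, this rests on only two pairs, and the core and the place differ together between them, so it does not separate the contribution of either or show that the change would carry to other cores or places.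

The compounds shown leave open whether a longer chain at these places would also stay within the scatter. They also leave open how an amine or a carboxylic acid on the same chain would behave on either core.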